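Spiro oxindole series: methylation of the ring amide nitrogen

The source may hold more compounds than are shown below. What is called first, only, known or untested is meant among the compounds shown, and "the series" means these compounds.

Measured so far in a functional assay on the whole organism (strain Wister albino) for inhibition, with Rattus norvegicus as the target, read by paw edema, with stated times of 1 h and 3 h, at a dose of 50 mg/kg by the intraperitoneal route; on this read-out higher numbers stand for more inhibition at the one dose given (going by the name of the read-out) and lower numbers for less inhibition:
compound 1 `CN1C/C(=C\c2ccccc2)C(=O)[C@]2(C1)[C@@H](c1ccccc1)CN(C)[C@@]21C(=O)Nc2ccccc21` — 71.4%
compound 2 `CN1C/C(=C\c2ccc(Br)cc2)C(=O)[C@]2(C1)[C@@H](c1ccc(Br)cc1)CN(C)[C@@]21C(=O)Nc2ccccc21` — 65.2%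
compound 3 `CN1C/C(=C\c2ccc(Cl)cc2)C(=O)[C@]2(C1)[C@@H](c1ccc(Cl)cc1)CN(C)[C@@]21C(=O)Nc2ccccc21` — 49.6%

Within these three, compound 3 stands lowest in this assay. The nearest number is that of compound 2, which lies beyond the scatter above compound 3, and compound 1 stands further still beyond it. For the measured compounds named here, no pair of measured compounds differs in only one place, so no single-change step has yet been seen in this set, and the two halogen pairs cannot be separated into single changes.

Compound 4 `CN1C/C(=C\c2ccc(Cl)cc2)C(=O)[C@]2(C1)[C@@H](c1ccc(Cl)cc1)CN(C)[C@@]21C(=O)N(C)c2ccccc21` is the next case and differs from compound 3 in one place: methyl in place of hydrogen on an amide-type nitrogen in a ring. Nothing measured here shows what a methyl in place of hydrogen on an amide-type nitrogen in a ring does in this assay, so the expectation rests on compound 3 alone. A step no larger than the usual scatter is expected, with no direction favoured. Compound 4 is estimated at 48%, with a range from 33% to 63%. That estimate means an expected step of a number 1.6 percentage points lower from compound 3 to compound 4 (within the scatter), which is expected to stay within the scatter.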

Compound 4, a percentage reported as inhibition, in the whole organism at one dose (the size of the read-out at that dose, not a potency): 44.5%
The estimate for compound 4 lay 3.5 percentage points above the measured number; measured number inside the range.
By their numbers in this assay, from the lowest: compounds 4 and 3 (each within the scatter of the next); then compounds 2 and 1 (each within the scatter of the next).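

In this assay, for the compounds shown here, methyl in place of hydrogen on the amide-type nitrogen in a ring gives the first single-change step in this set: a number 5.1 percentage points lower from compound 3 to compound 4 (within the scatter). With the chlorine-bearing aryl groups held fixed, the amide hydrogen can therefore give way to methyl at this position without a step beyond the scatter. Nothing measured here explains the size of this step.

On these data alone, it remains open whether the same methyl change would also stay within the scatter when made on compound 1, with its unsubstituted phenyl groups, or on compound 2, with its bromine-bearing aryl groups. Also open, as far as these compounds go, is how a longer chain such as n-butyl, a benzyl group or an acetyl group on this nitrogen would read out against compound 3.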